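Anilino replacement on the shared core: compound 4

A few compounds are considered here, and "the series" means these few. Any claim that something is new, unique, unknown or untested is made for them only; others in the source may bear on it.

Measured in a functional assay on OVCAR-4 cells (Homo sapiens) for inhibition, read by sulforhodamine B assay, with a stated time of 48 h; on this read-out higher numbers stand for weaker inhibition of growth and lower numbers for stronger inhibition of growth:
compound 1 `CN1CCN(CCCOc2cccc3nc(Nc4ccc(Cl)c(C(F)(F)F)c4)ccc23)CC1` gives 2730 nM
compound 2 `CC(C)c1ccc(Nc2ccc3c(OCCCN4CCN(C)CC4)cccc3n2)cc1` gives 13900 nM
compound 3 `CN1CCN(CCCOc2cccc3nc(Nc4cc(Cl)cc(Cl)c4)ccc23)CC1` gives 2550 nM

Compound 2 stands highest of the three numbers in this assay; compound 1 and compound 3 sit together within the scatter, as a 1.1-fold lower number from compound 1 to compound 3 (0.03 log units; within the scatter) shows. The steps that set compound 2 apart are a 5.1-fold higher number from compound 1 to compound 2 (0.71 log units; beyond the scatter) and a 5.5-fold lower number from compound 2 to compound 3 (0.74 log units; beyond the scatter), both modest but beyond the scatter.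

Compound 4 `CN1CCN(CCCOc2cccc3nc(Nc4cccc(Cl)c4)ccc23)CC1` is to be measured in this assay. Relative to compound 2 the change is 3-chlorophenyl in place of 4-isopropylphenyl on a nitrogen on an aromatic ring. The step most directly bearing on it is a 5.5-fold lower number from compound 2 to compound 3 (0.74 log units; beyond the scatter), where the 3,5-dichlorophenyl also replaced the 4-isopropylphenyl; a 5.1-fold higher number from compound 1 to compound 2 (0.71 log units; beyond the scatter) points the same way. A drop of similar size is therefore expected, a 4.0-fold lower number from compound 2 to compound 4 (0.60 log units; beyond the scatter), landing compound 4 near the other two chlorine-bearing anilines rather than near compound 2. Compound 4 is estimated at 3500 nM, with an expected range of 1500 nM to 9000 nM.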

Compound 4, concentration for 50% growth inhibition: 1940 nM
Compound 4: middle estimate off by 1.8-fold (0.26 log units), on the high side; the measured number falls inside the stated range.
By their numbers in this assay, from the lowest: compounds 4, 3 and 1 (each within the scatter of the next); then compound 2.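

The 3-chlorophenyl alone is enough to separate this aniline from the 4-isopropylphenyl of compound 2, with a 7.2-fold lower number from compound 2 to compound 4 (0.86 log units; beyond the scatter). Additional halogen substitution shows no readable gain: hydrogen in place of chloro gives a 1.3-fold lower number from compound 3 to compound 4 (0.12 log units; within the scatter), and 3-chlorophenyl in place of 4-chloro-3-(trifluoromethyl)phenyl gives a 1.4-fold lower number from compound 1 to compound 4 (0.15 log units; within the scatter). No available evidence bears on this difference.

On these data alone, whether the high number of compound 2 goes with the isopropyl group itself or with the absence of chlorine stays open. A methoxy or an amine on that phenyl ring would test this.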